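This account rests on a few compounds, and the source may have more. Where it says the series, first, only, none or still open, it means among the compounds named here.

Of the compounds shown here, three that share one core have been tested in a functional assay on A549 cells (Homo sapiens) for antiproliferative activity, read by MTT assay, with a stated time of 24 h; a higher number here means a weaker inhibitor, a lower number a stronger inhibitor. Compound 1 `Clc1ccc(C2=NN(c3ccc(-c4ccccc4)nn3)C(c3ccccc3)C2)cc1` gives 96700 nM in this assay. Compound 3 `COc1ccc(C2CC(c3ccc(Cl)cc3)=NN2c2ccc(-c3ccccc3)nn2)cc1` carries methoxy in place of hydrogen on an aromatic carbon and gives 100000 nM, which makes a 1.0-fold higher number from compound 1 to compound 3 (0.01 log units; within the scatter). Compound 2 `Clc1ccc(C2=NN(c3ccc(-c4ccccc4)nn3)C(c3ccc(Cl)cc3)C2)cc1` is reported only as a limit of the measurement, > 100000 nM, and so no number is known for it. That limit is the limit of > 100000 nM in this assay, at which 1 of the 3 values shown sits.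

Compound 4 `COc1ccc(C2=NN(c3ccc(-c4ccccc4)nn3)C(c3ccccc3)C2)cc1` has not yet been measured. It differs from compound 1 by methoxy in place of chloro on an aromatic carbon. The same change occurs once more among these compounds, from compound 2 to compound 3, where it reads (methoxy in place of chloro on an aromatic carbon); the place of the change is described in the same words for both pairs, so this is the same change made on two different cores. Those two cores differ by hydrogen in place of chloro on an aromatic carbon. The measured step for this change is a number no higher from compound 2 to compound 3 (the limit leaves the size open), and it therefore says little about size. Within this set every number lies close to the upper edge of what the assay reports, and the only step with a readable size, a 1.0-fold higher number from compound 1 to compound 3 (0.01 log units; within the scatter), stays within the scatter.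

Compound 4 is expected to show a 1.0-fold higher number from compound 1 to compound 4 (0.01 log units; within the scatter). This expectation rests on compound 1 at 96700 nM and on the small step of a 1.0-fold higher number from compound 1 to compound 3 (0.01 log units; within the scatter) seen for a related change on the same core. The estimate for compound 4 is 100000 nM, between 50000 nM and 200000 nM.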

Compound 4, half-maximal inhibitory concentration: 75900 nM
For compound 4 the middle estimate is 1.3-fold (0.12 log units) above the measured one, and the stated range covers the measured number.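

Replacing the 4-chlorophenyl of compound 1 with 4-methoxyphenyl gives a 1.3-fold lower number from compound 1 to compound 4 (0.11 log units; within the scatter) in this assay, so on this core the change from chloro to methoxy moves the number no further than repeated measurements of the same compound might. Setting this result beside the same change on the second core does not settle whether the two cores respond alike: the same change on two cores in this assay, a number no higher (the limit leaves the size open) from compound 2 to compound 3 and a 1.3-fold lower number (0.11 log units; within the scatter) from compound 1 to compound 4; the limit leaves it open whether they differ Compound 2 stands at > 100000 nM, which is a limit of the assay and not a number, so the step on that core cannot be read, and the series neither shows that the small step carries over to the second core nor shows that it fails to.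

The compounds shown carry only hydrogen, chloro or methoxy at the varied aromatic carbons, so it remains open whether an amine or a carboxylic acid in the place of the methoxy would give a step beyond the scatter from compound 1, which gives 96700 nM. A pair on the second core with two readable numbers would also be needed to compare the chloro-to-methoxy change across cores.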